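The compounds below may be only part of what the source reports. "The series", "measured", "known", "first", "only" and "open" are said of these compounds alone.

Measured compounds:
compound 1, `CCCCCN(C1=NCCN1)c1c(Br)cccc1Br`, gives 11 in a physicochemical assay for acid dissociation;
compound 2, `CC(C)CN(C1=NCCN1)c1c(Br)cccc1Br`, gives 11 in this assay.

Compound 2 stands level with compound 1 at the digits shown. Among the compounds with values here, the one measured step, no change at the digits printed from compound 1 to compound 2 (within the scatter), swapped one saturated chain group for another on the chain carbon bound to the nitrogen on the aromatic ring and left the read-out where it was, within the scatter.

Compound 3, `Brc1cccc(Br)c1N(CC1CCCCC1)C1=NCCN1`, is not yet measured. It differs from compound 2 in one place: cyclohexyl in place of isopropyl on a saturated chain carbon bound to a nitrogen on an aromatic ring.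

This is the same kind of change as the measured step: a saturated, carbon-only group without donors, acceptors or charge is exchanged for another such group at the same place. That step was flat, so the change from compound 2 to compound 3 is expected to be flat too, no change at the digits printed from compound 2 to compound 3 (within the scatter), with no movement beyond the scatter in either direction. For compound 3 the estimated value in this assay is 11, with a range from 10.5 to 11.5.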

Compound 3, acid dissociation constant: 11.2
Estimate against measurement, compound 3: 0.20 log units below; low and high end bracket the measured number.
By their numbers in this assay, from the lowest: compounds 1, 2 and 3 (each within the scatter of the next).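

In this assay, the exchange of isopropyl for cyclohexyl reads as a number 0.20 log units higher from compound 2 to compound 3 (within the scatter) and the exchange of butyl for cyclohexyl reads as a number 0.20 log units higher from compound 1 to compound 3 (within the scatter) at this place on a saturated chain carbon bound to a nitrogen on an aromatic ring. The earlier pair compared only open chains, whereas these steps bring in a six-membered non-aromatic ring of carbon only and take the group from 3 heavy atoms in isopropyl to 6 in cyclohexyl, and the read-out still stays within the scatter for all three compounds. No supporting information is available to explain this flat result.

The compounds shown leave open whether an amine or a carboxylic acid at this place would shift the number in this assay beyond the scatter, since every group here is made of carbon alone. A phenyl ring or a much longer chain at the same place also remains an open case, as does any change to the shared core.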